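A few compounds are considered here, and "the series" means these few. Any claim that something is new, unique, unknown or untested is made for them only; others in the source may bear on it.

Of the compounds shown here, three have been measured in a functional assay on HuCC-A1 cells (Homo sapiens) for cytotoxicity, read by MTT assay, with a stated time of 48 h; a higher number here means a weaker inhibitor, a lower number a stronger inhibitor. Compound 1 `COc1cc2c(cc1OC)CN(S(=O)(=O)c1ccc(-n3cc(COc4ccc(C=O)cc4)nn3)cc1)CC2` gives 31100 nM. Compound 2 `O=c1cc(OCc2cn(-c3ccc(S(=O)(=O)N4CCc5ccccc5C4)cc3)nn2)c2ccccc2o1`, which carries a different core and a different aryl ether, gives 24800 nM in this assay. Compound 3 `COc1cc2c(cc1OC)CN(S(=O)(=O)c1ccc(-n3cc(COc4ccccc4C)nn3)cc1)CC2` gives 39700 nM in this assay. Its number sits within the scatter of both compound 1 and compound 2, so the three measured compounds cannot be told apart. For the measured compounds named here, the single one-point comparison, a 1.3-fold higher number from compound 1 to compound 3 (0.11 log units; within the scatter), exchanges a 4-formylphenyl for a 2-methylphenyl without moving the number beyond the scatter.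

Compound 4 `COc1cc2c(cc1OC)CN(S(=O)(=O)c1ccc(-n3cc(COc4cc(C=O)ccc4OC)nn3)cc1)CC2` differs from compound 3 in one place: 5-formyl-2-methoxyphenyl in place of 2-methylphenyl on an oxygen on a saturated carbon. Going by the values given here, the only measured step that bears on this change is a 1.3-fold higher number from compound 1 to compound 3 (0.11 log units; within the scatter), which lay within the scatter, and no measured pair speaks to the methoxy part of the entering group. The expected step is therefore a 1.2-fold lower number from compound 3 to compound 4 (0.08 log units; within the scatter), nothing beyond the scatter. The estimate for compound 4 in this assay is 33000 nM, with a range from 15000 nM to 75000 nM.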

Compound 4, half-maximal inhibitory concentration: 76200 nM
Compound 4: middle estimate off by 2.3-fold (0.36 log units), on the low side, outside the stated range (above it).
By their numbers in this assay, from the lowest: compounds 2, 1, 3 and 4 (each within the scatter of the next, the first and the last beyond it).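

In this assay, the aryl group on the oxygen on a saturated carbon now gives its first step beyond the scatter (a 2.5-fold higher number from compound 1 to compound 4 (0.39 log units; beyond the scatter)), though a modest one, with 5-formyl-2-methoxyphenyl in place of 4-formylphenyl. The same entering group stays within the scatter against 2-methylphenyl (a 1.9-fold higher number from compound 3 to compound 4 (0.28 log units; within the scatter)), so this position is not shown to be entirely silent, but the effect can be read only against compound 1. Nothing shown gives a reason for this step.

The step from compound 1 to compound 4 leaves the methoxy group and the altered placing of the formyl group unseparated, so neither can be credited on its own. Going by these compounds, it also remains open how an amine or a carboxylic acid in place of the formyl group would read in this assay.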